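Replacing the Chlorophenyl Ring on the Core with Pyridin-3-yl

A few compounds are considered here, and "the series" means these few. Any claim that something is new, unique, unknown or untested is made for them only; others in the source may bear on it.

Compound 1 `CCCCCCCCc1ccc(OCC(=O)Cn2nnc(SC)n2)cc1` in an ADME assay on S9 fraction from liver (Rattus norvegicus) for metabolic stability, read by LC-MS, using NADPH, with a stated time of 30 min; a lower number here means that less of the compound is left, a higher number that more of the compound is left: compound 1 gives < 5%, a limit of the assay (the limit of < 5% in this assay, at which 1 of the 3 values shown sits).
Compound 2 `CCCCCCCCc1ccc(OCC(=O)Cn2nnc(-c3ccc(Cl)cc3)n2)cc1`: compound 2 gives 74%.
Compound 3 `CCCCCCCCc1ccc(OCC(=O)Cn2nnc(-c3cccc(S(=O)(=O)N(C)C)c3)n2)cc1`: compound 3 gives 9%.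

Compound 2 holds the highest of the two numbers shown; its nearest neighbour is compound 3, and a number 65 percentage points lower from compound 2 to compound 3 (beyond the scatter). Compound 4 `CCCCCCCCc1ccc(OCC(=O)Cn2nnc(-c3cccnc3)n2)cc1` has not yet been measured in this assay. Against compound 2 the change is pyridin-3-yl in place of 4-chlorophenyl on an aromatic carbon. Two measured steps exchange the group on this same aromatic carbon: a number at least 69 percentage points higher from compound 1 to compound 2 (beyond the scatter) and a number 65 percentage points lower from compound 2 to compound 3 (beyond the scatter). Both are large, and the second shows that swapping one six-membered aromatic ring for another can move the read-out a long way in this series. The pyridin-3-yl ring of compound 4 is a six-membered aromatic ring with 1 hetero atom, which places it between the 4-chlorophenyl of compound 2 and the 3-(dimethylsulfamoyl)phenyl of compound 3. Compound 4 is therefore expected to sit lower than compound 2, with a number 34 percentage points lower from compound 2 to compound 4 (beyond the scatter) as the estimated step. The estimate for compound 4 is 40%, with a range from 10% to 75%.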

Compound 4, percent of the compound remaining: 12%
Compound 4: middle estimate off by 28 percentage points, on the high side; measured number inside the range.
By their numbers in this assay, from the lowest: compounds 3 and 4 (each within the scatter of the next); then compound 2. At a limit, below all of these: compound 1.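

Compound 3 left open whether the fall from compound 2 required the dimethylsulfamoyl group, but pyridin-3-yl carries no such group and the fall remains: a number 62 percentage points lower from compound 2 to compound 4 (beyond the scatter). The two low compounds cannot be told apart, with a number 3 percentage points higher from compound 3 to compound 4 (within the scatter), so among the three six-membered aromatic rings shown on this carbon, only the 4-chlorophenyl of compound 2 keeps a high number. Compound 1 stands at a limit of the assay, so its step to compound 4, a number at least 7 percentage points higher from compound 1 to compound 4 (that floor lies within the scatter), cannot be read as a real difference: the limit of < 5% in this assay, at which 1 of the 4 values shown sits.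

On these data alone, what remains open is whether the high number of compound 2 rests on the chlorine atom or on the all-carbon ring, a question that an unsubstituted phenyl or a 4-methylphenyl ring would address. A pyridin-4-yl ring would show whether the place of the ring nitrogen matters here.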